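The source may hold more compounds than are shown below. What is called first, only, known or untested is meant among the compounds shown, and "the series" means these compounds.

Measured compounds:
compound 1 `N/C(=N\NC(=S)N1CCCC1)c1ccc(F)cn1` gives 86.6% in a functional assay on A-375 cells (Homo sapiens) for cytotoxicity, read by MTT assay, with a stated time of 72 h, tested at 100 uM; a higher number here means more inhibition of growth at the concentration tested, a lower number less inhibition of growth
compound 2 `Cc1cccc(/C(N)=N/NC(=S)N2CCCC2)n1` gives 66.3% in this assay

Compound 2 stands lowest of the two numbers in this assay; its nearest neighbour is compound 1, whose number lies higher by a margin beyond the usual scatter. Among the compounds with values here, compound 1 and compound 2 differ from each other in more than one place, so no single step between them can be read, and only their two values can be set side by side.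

Compound 3 `N/C(=N\NC(=S)N1CCCC1)c1ccccn1` has not yet been measured in this assay. It differs from compound 2 by hydrogen in place of methyl on an aromatic carbon. Within the data shown here, no step between measured compounds follows this change, so no measured guide exists for its size. Among the measured compounds shown here, the account therefore rests on the two values alone: compound 2 gives 66.3% and the only other compound, compound 1, gives 86.6%, both with their substituent on the same ring but at different places. For compound 3 the number in this assay is estimated at 75%, with a range from 55% to 92%. This estimate means an expected step of a number 8.7 percentage points higher from compound 2 to compound 3 (within the scatter), upward but of modest size, which may or may not exceed the scatter.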

Compound 3, percent growth inhibition at one concentration: 87.8%
For compound 3 the middle estimate is 12.8 percentage points below the measured one, and the stated range covers the measured number.
By their numbers in this assay, from the lowest: compound 2; then compounds 1 and 3 (each within the scatter of the next).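

In this assay, hydrogen in place of methyl on the aromatic carbon next to the ring nitrogen, meta to a large group, gives a number 21.5 percentage points higher from compound 2 to compound 3 (beyond the scatter), so the lower number of compound 2 can now be tied to this single methyl, which the earlier pair, differing in more than one place, could not show. Hydrogen in place of fluoro on an aromatic carbon gives a number 1.2 percentage points higher from compound 1 to compound 3 (within the scatter), so this change leaves no difference that can be read beyond the scatter, and the fluoro of compound 1 neither adds to nor takes away from the number in any measurable way. Nothing at hand explains why the methyl goes with less inhibition of growth.

The compounds shown leave open whether the loss belongs to methyl alone or would also follow another group on the carbon next to the ring nitrogen, such as a chloro, a methoxy or an amine. They also leave open whether a fluoro at that same place would behave as hydrogen does or as methyl does.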